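Formyl in place of (propylamino)methyl in a cytotoxicity series

The source may hold more compounds than are shown below. What is called first, only, known or untested is meant among the compounds shown, and "the series" means these compounds.

Compound 1 `CCCNCc1cccc(OCCCCCC(=O)OCC)c1` and compound 2 `CCCNCc1ccc(OCCCCCC(=O)OCC)cc1` have the same atoms joined differently; the difference between the two cores is not broken down here. In an ADME assay on Raji cells (Homo sapiens) for cytotoxicity, read by CellTiter-Glo and resazurin assay, with a stated time of 72 h (on this read-out higher numbers stand for an effect only at larger amounts of compound and lower numbers for an effect already at smaller amounts), compound 1 gives only a limit, > 26000 nM. Compound 2 likewise gives only a limit in this assay, > 26000 nM. Compound 3 `CCOC(=O)CCCCCOc1cccc(C=O)c1` carries formyl in place of (propylamino)methyl on an aromatic carbon; in this assay compound 3 again gives only a limit, > 26000 nM. The step that the two limits leave unreadable from compound 1 to compound 3 stays unreadable because of the limit of > 26000 nM in this assay, at which 3 of the 3 values shown sit.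

Compound 4 `CCOC(=O)CCCCCOc1ccc(C=O)cc1` is not yet measured. It carries formyl in place of (propylamino)methyl on an aromatic carbon. The surroundings of the place differ: in compound 3 the formyl sits meta to a large group, in compound 4 para to a large group, so this is the same kind of change, not the same change. For compound 4 the step that the limit leaves unreadable from compound 2 to compound 4 is expected to be small, since the same kind of change gave a step that the two limits leave unreadable from compound 1 to compound 3. Compound 4 is estimated at 30000 nM in this assay, with an expected range from 10000 nM to 100000 nM, most probably reported again as a limit.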

Compound 4, half-maximal effective concentration: > 26000 nM
Compound 4 was reported as a limit; the forecaster's own chance of this, stated with the estimate: 85%; the middle value is on the limit's open side.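

No step can be read from compound 2 to compound 4, because both stand only as limits: the limit of > 26000 nM in this assay, at which 4 of the 4 values shown sit.

The compounds shown leave open whether formyl in place of (propylamino)methyl changes the read-out in this assay in either surrounding, and whether any of these four compounds has a measurable effect there.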